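A few compounds are considered here, and "the series" means these few. Any claim that something is new, unique, unknown or untested is made for them only; others in the source may bear on it.

In a functional assay on the whole organism with Mus musculus as the target (on this read-out lower numbers stand for an effect already at smaller amounts and higher numbers for an effect only at larger amounts of compound), compound 1 (`OC1CCN(c2ccc(-c3ccccc3)nn2)CC1`) gives 83 mg/kg while compound 2 (`Cc1ccc(-c2ccc(N3CCC(O)CC3)nn2)c(Cl)c1`) gives 17 mg/kg and compound 3 (`OC1CCN(c2ccc(-c3cc(Cl)ccc3Cl)nn2)CC1`) gives 131 mg/kg as its result. Compound 1 thus sits in the upper part of this small set. Its number cannot be told apart from that of compound 3, as the two lie within the usual scatter, whereas compound 2 has a lower number by a margin beyond the scatter.

Compound 4 (`OC1CCN(c2ccc(-c3ccccc3F)nn2)CC1`) has not yet been measured. It departs from compound 1 in a single place, and the change is fluoro in place of hydrogen on an aromatic carbon in the sense of fluoro in place of hydrogen on an aromatic carbon. Among the measured compounds shown here, no two measured compounds differ in only one place, so no direct example shows what such a swap does in this assay here. A modest step is expected, leaning slightly toward a lower number, with compound 2 at 17 mg/kg showing that lower numbers are reachable in this set. The estimated step of a 1.5-fold lower number from compound 1 to compound 4 (0.18 log units; within the scatter) is expected to stay within the scatter. For compound 4 the estimate is 55 mg/kg with an expected range from 20 mg/kg to 130 mg/kg once it is measured.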

Compound 4, dose for half-maximal effect: 30 mg/kg
For compound 4 the middle estimate is 1.8-fold (0.26 log units) above the measured one, within the range that was stated.
By their numbers in this assay, from the lowest: compounds 2 and 4 (each within the scatter of the next); then compounds 1 and 3 (each within the scatter of the next).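

Among the compounds shown here, until now, no two measured compounds differed in only one place, so nothing showed what a single small swap could do to this whole-animal result; compound 4 supplies that first direct reading. In this assay, fluoro in place of hydrogen on an aromatic carbon, ortho to a large group, gives a 2.8-fold lower number from compound 1 to compound 4 (0.44 log units; beyond the scatter), so adding one fluorine atom at this position is enough to move the number beyond the usual scatter, even though the step is rated modest. No separate measurement here explains what lies behind this step.

This single step cannot show whether fluoro would have a similar effect on other carbons of that ring, or what a different group at the same place, such as methoxy, a nitrile or an amine, would do. From the compounds shown here alone, compound 2 and compound 3 each differ from compound 1 in more than one place, so the contribution of each of their separate changes also remains open.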